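A few compounds are considered here, and "the series" means these few. Any claim that something is new, unique, unknown or untested is made for them only; others in the source may bear on it.

Measured compounds:
Compound 1 `C[C@]1(CN2CCc3nc(-c4ccc(F)cc4F)ccc3C2)Cn2cc([N+](=O)[O-])nc2O1`: 12.5 ug/mL
Compound 2 `C[C@]1(CN2CCc3nc(-c4cc(F)cc(F)c4)ccc3C2)Cn2cc([N+](=O)[O-])nc2O1`: > 32 ug/mL (a limit)

In an ADME assay on Vero cells (Chlorocebus sabaeus) for cytotoxicity, read by MTT assay, with a stated time of 72 h (on this read-out lower numbers stand for higher toxicity in this test and higher numbers for lower toxicity in this test), compound 2 has no exact number, only a limit: it stands at the limit of > 32 ug/mL in this assay, at which 1 of the 2 values shown sits. Compound 3 `C[C@]1(CN2CCc3nc(-c4cccc(F)c4F)ccc3C2)Cn2cc([N+](=O)[O-])nc2O1` differs from compound 2 in one place, (2,3-difluorophenyl in place of 3,5-difluorophenyl on an aromatic carbon). In words, 2,3-difluorophenyl takes the place of 3,5-difluorophenyl on an aromatic carbon next to the ring nitrogen.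

Going by the values given here, one measured step bears on this change: an at least 2.5-fold higher number from compound 1 to compound 2 (0.40 log units; beyond the scatter). It swapped one difluorophenyl pattern for another at the same place, so the pattern alone can shift the number. Compound 3 gives up the 3,5-difluorophenyl found in compound 2, so it may lose some of that gain, though the direction is not certain. The expected change is an at least 1.6-fold lower number from compound 2 to compound 3 (0.20 log units; that floor lies within the scatter). For compound 3 the estimated value is 20 ug/mL, with an expected range from 9 ug/mL to 45 ug/mL.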

Compound 3, half-maximal cytotoxic concentration: > 32 ug/mL
Compound 3 was reported as a limit; the forecaster's own chance of this, stated with the estimate: 40%; middle value at least 1.6-fold (0.20 log units) from the limit.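

In this assay compound 3 gives > 32 ug/mL as a limit, not an exact number. Replacing 2,4-difluorophenyl with 2,3-difluorophenyl gives an at least 2.5-fold higher number from compound 1 to compound 3 (0.40 log units; beyond the scatter) and so the higher number is not tied to 3,5-difluorophenyl alone. The step between compound 2 and compound 3 cannot be read, since both sit at one limit: the limit of > 32 ug/mL in this assay, at which 2 of the 3 values shown sit.

Going by these compounds, how far past that limit either compound lies stays open, and so does which of these two fluorine patterns gives the higher number. Also open, on these data alone, is how this position, on an aromatic carbon next to the ring nitrogen, would respond if an amine or a carboxylic acid took the place of the difluorophenyl group.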